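Cyclopropyl for Hydroxyethyl: Expected Vero Cell Cytotoxicity

The source may hold more compounds than are shown below. What is called first, only, known or untested is meant among the compounds shown, and "the series" means these compounds.

Compound 1, `[N-]=[N+]=N[C@H]1C[C@H](n2cnc3c(NCCO)nc(N)nc32)O[C@@H]1CO`, was examined in an ADME assay on Vero cells (Chlorocebus sabaeus) for cytotoxicity, with a stated time of 5 days; on this read-out higher numbers stand for weaker inhibition and lower numbers for stronger inhibition. In this assay compound 1 gave only a limit of the assay, > 100000 nM. A second compound, compound 2, `COc1nc(Cl)nc2c1ncn2[C@H]1C[C@H](N=[N+]=[N-])[C@@H](CO)O1`, was tested as well. In this assay compound 2 likewise reached only a limit, > 100000 nM. Compound 1 therefore stands at the limit alongside compound 2, and no number separates the two. Compound 3, `[N-]=[N+]=N[C@H]1C[C@H](n2cnc3c(NC4CC4)nc(N)nc32)O[C@@H]1CO`, has not yet been measured in this assay. It differs from compound 1 by cyclopropyl in place of 2-hydroxyethyl on a nitrogen on an aromatic ring. For the measured compounds named here, no measured step between two compounds is available, so the effect of such a change cannot be read from the data. Compound 3 is expected to sit at the same limit because of the limit of > 100000 nM in this assay, at which 2 of the 2 values shown sit. The estimated step is a number no higher from compound 1 to compound 3 (the limit leaves the size open), no change beyond the scatter. Compound 3 is thus estimated at 100000 nM, between 50000 nM and 300000 nM.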

Compound 3, half-maximal inhibitory concentration: > 100000 nM
Compound 3: no number, only a limit; the forecaster's own chance of this, stated with the estimate: 80%; the middle value sits exactly at the limit.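

Compound 3 gives > 100000 nM in this assay, which is a limit of the assay and not a number. For the compounds shown here, compound 1 also stands at a limit, so no step from compound 1 to compound 3 can be read. The compounds shown leave open whether cyclopropyl in place of 2-hydroxyethyl on a nitrogen on an aromatic ring changes the read-out at all.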